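The compounds below may be only part of what the source reports. "The series", "measured", "known", "first", "only" and "open" are said of these compounds alone.

Measured compounds:
compound 1 `C[C@@H]1CCCN1c1c(C#N)c2c(N)ncnc2n1C`: 15 nM
compound 2 `C[C@@H]1CCCN1c1c(C#N)c2c(N)nc(N)nc2n1C`: 248 nM

In an assay on isolated protein for inhibition of Leucine-rich repeat serine/threonine-protein kinase 2 (Homo sapiens), read by TR-FRET and LanthaScreen, with stated times of 50 min and 30 min, in the presence of a further agent that is not named here (on this read-out lower numbers stand for stronger inhibition and higher numbers for weaker inhibition), compound 1 gives the lowest of the two numbers; the nearest is compound 2, reached by a 17-fold higher number from compound 1 to compound 2 (1.22 log units; beyond the scatter), which is amino in place of hydrogen on an aromatic carbon.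

Compound 3 `C[C@@H]1CCCN1c1[nH]c2ncnc(N)c2c1C#N` has not been measured. Relative to compound 1 the change is hydrogen in place of methyl on an aromatic nitrogen, the nitrogen of the five-membered ring of the shared core, the substituent pattern on the carbons being kept.

Within the data shown here, no measured step bears on this change. Among the measured compounds shown here, the only step in hand concerns an amino group on an aromatic carbon and says nothing about the ring nitrogen. The expectation for compound 3 therefore rests on compound 1 alone, with wide uncertainty in both directions. A step of modest size is expected, a 2.0-fold higher number from compound 1 to compound 3 (0.30 log units; within the scatter), somewhat toward a higher number. The estimate for compound 3 is 30 nM, within 8 nM to 120 nM.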

Compound 3, half-maximal inhibitory concentration: 166 nM
Beside the measured number, compound 3's estimate is 5.5-fold (0.74 log units) below it, and the stated range ends below it.
By their numbers in this assay, from the lowest: compound 1; then compounds 3 and 2 (each within the scatter of the next).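

In this assay, the methyl on the aromatic nitrogen of the five-membered ring proves to be far from a silent substituent: exchanging it for hydrogen gives an 11-fold higher number from compound 1 to compound 3 (1.04 log units; beyond the scatter) and thus moves the number beyond the scatter. Until now the only step in the series lay on a carbon of the shared core, a 17-fold higher number from compound 1 to compound 2 (1.22 log units; beyond the scatter) on adding amino, so this is the first reading at the ring nitrogen, and both single changes shown from compound 1 raise the number. Nothing in hand accounts for the size of the step at the nitrogen.

At this nitrogen only methyl and hydrogen are shown, so it remains open whether ethyl, a longer chain or a 2-hydroxyethyl group would keep, lower or further raise the number of compound 1. Also open, going by these compounds, is whether the step from methyl to hydrogen keeps its size with the added amino group of compound 2 in place, and whether another amine, such as morpholine, can stand in for the 2-methylpyrrolidin-1-yl group.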